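Acyl group variation on the shared core: compound 3 to compound 4

This account rests on a few compounds, and the source may have more. Where it says the series, first, only, none or still open, it means among the compounds named here.

Three compounds have numbers in an assay on HEK293 cells for negative allosteric modulation of metabotropic glutamate receptor 5 (Homo sapiens), read by FLIPR; on this read-out lower numbers stand for stronger inhibition and higher numbers for weaker inhibition. Compound 1 `Cc1cccc(S(=O)(=O)N2CC(c3nc(-c4cccc(Cl)c4)no3)C2)c1` gives 390 nM in this assay, and compound 2 `Cc1ccc(S(=O)(=O)N2CC(c3nc(-c4cccc(Cl)c4)no3)C2)cc1` gives 920 nM. Going by the values given here, the only single-point step among the measured compounds, a 2.4-fold higher number from compound 1 to compound 2 (0.37 log units; beyond the scatter), concerns the aryl group on the sulfonyl sulfur. Compound 3 `O=C(C1CCCO1)N1CC(c2nc(-c3cccc(Cl)c3)no2)C1` carries an oxolan-2-yl carbonyl in place of the sulfonyl groups and gives 890 nM in this assay; it holds the second highest of the three numbers, sits within the scatter of compound 2 and gives a higher number than compound 1.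

Compound 4 `O=C(C1CCC2(CCC2)CC1)N1CC(c2nc(-c3cccc(Cl)c3)no2)C1` is not yet measured. Relative to compound 3 the change is a group of 9 heavy atoms (9 carbon; one four-membered non-aromatic ring of carbon only, one six-membered non-aromatic ring of carbon only) in place of a group of 5 heavy atoms (4 carbon, 1 oxygen; one five-membered non-aromatic ring with 1 hetero atom), on a carbonyl carbon. Among the compounds with values here, no measured step touches the group on the carbonyl carbon; the one measured step, a 2.4-fold higher number from compound 1 to compound 2 (0.37 log units; beyond the scatter), lies on the sulfonyl side and therefore bears only loosely on this change, showing that a modest swap of a peripheral group can shift the number beyond the scatter. With nothing pointing in either direction, the expectation for a 1.3-fold lower number from compound 3 to compound 4 (0.10 log units; within the scatter) is a step of no clear sign, and compound 4 is estimated at 700 nM in this assay, within the range 200 nM to 2500 nM.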

Compound 4, half-maximal inhibitory concentration: > 10000 nM
Compound 4 gave a limit, no number; the forecaster's own chance of this, stated with the estimate: 5%; at least 14-fold (1.15 log units) between middle value and limit.
By their numbers in this assay, from the lowest: compound 1; then compounds 3 and 2 (each within the scatter of the next). At a limit, above all of these: compound 4.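

In this assay, going by these compounds alone, the group on the carbonyl carbon proves to be a sensitive place: replacing oxolan-2-yl with the all-carbon group of 9 heavy atoms gives an at least 11-fold higher number from compound 3 to compound 4 (1.05 log units; beyond the scatter), a large step, whereas the only earlier step, on the sulfonyl side, was the modest 2.4-fold higher number from compound 1 to compound 2 (0.37 log units; beyond the scatter). Compound 4 gives only a limit of the assay and not a number, so the true size of the step stays undefined: the limit of > 10000 nM in this assay, at which 1 of the 4 values shown sits. The change alters several things at once, with the heavy-atom count rising, the single oxygen-containing five-membered ring giving way to a four-membered and a six-membered carbon ring, and the hydrogen-bond acceptors on the group going from 1 to 0, and this single step does not separate these differences.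

The compounds shown leave open which of these differences carries the loss, and a plain cyclohexyl or an oxan-4-yl group on the same carbonyl carbon would help to separate ring size, the second ring and the ring oxygen. Also open, from the compounds shown here alone, is whether a hydroxyl or an amine on the six-membered ring would bring the number back towards that of compound 3.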